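The source may report more compounds than this note shows. Statements on the series, on what has been measured and on what is new or still open speak of the compounds shown alone.

Working notes on the series. Compound 1 `N#C/C(=C\c1c(-c2ccccc2)[nH]c2ccccc12)C(=O)c1ccccc1` and compound 2 `COc1ccc(-c2[nH]c3ccccc3c2/C=C(\C#N)S(=O)(=O)c2ccccc2)cc1` share a core with compound 3 `COc1ccc2[nH]c(-c3ccccc3)c(/C=C(\C#N)S(=O)(=O)c3ccccc3)c2c1`, and all three have been run in a functional assay on NCI-H522 cells (Homo sapiens) for inhibition, read by sulforhodamine B assay, with a stated time of 48 h; a higher number here means a weaker inhibitor of growth, a lower number a stronger inhibitor of growth. In this assay compound 1 gives 4000 nM, compound 2 gives 3000 nM and compound 3 gives 4000 nM. On these three numbers compound 3 stands level with compound 1 at the digits shown, the pair together forming the highest of the three; the gap from compound 3 to compound 2 lies within the scatter, so the three values cannot be ordered.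

Compound 4 `N#C/C(=C\c1c(-c2ccccc2)[nH]c2ccccc12)S(=O)(=O)c1ccccc1` is the next member to be tested in this assay. Against compound 3 the change is hydrogen in place of methoxy on an aromatic carbon. Going by the values given here, no measured pair in the set isolates this change; the only guide is that compound 2 carries a methoxy on a different ring and compound 1 lacks it altogether, and both sit within the scatter of compound 3. The step from compound 3 to compound 4 is therefore expected to be a 1.1-fold lower number from compound 3 to compound 4 (0.06 log units; within the scatter), none beyond the scatter. For compound 4 the estimate in this assay is 3500 nM, with a range from 1500 nM to 8000 nM.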

Compound 4, concentration for 50% growth inhibition: 4600 nM
Compound 4: middle estimate off by 1.3-fold (0.12 log units), on the low side; the measured number falls inside the stated range.
By their numbers in this assay, from the lowest: compounds 2, 1, 3 and 4 (each within the scatter of the next).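

In this assay, hydrogen in place of methoxy on the aromatic carbon of the fused system reads as a 1.2-fold higher number from compound 3 to compound 4 (0.06 log units; within the scatter) and the same exchange on the other ring reads as a 1.5-fold higher number from compound 2 to compound 4 (0.19 log units; within the scatter), so the methoxy does not register beyond the scatter at either place. Phenylsulfonyl in place of benzoyl on the double-bonded chain carbon, now seen as a single change, reads as a 1.2-fold higher number from compound 1 to compound 4 (0.06 log units; within the scatter) and likewise stays within the scatter. Nothing at hand bears on why these steps are so small.

The compounds shown leave open whether an amine, a carboxylic acid or a longer alkoxy chain in place of that methoxy would move the number beyond the scatter. They also leave open whether an ester or an amide on that chain carbon would do so.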